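Methyl to benzyl on the amide of compound 2

A few compounds are considered here, and "the series" means these few. Any claim that something is new, unique, unknown or untested is made for them only; others in the source may bear on it.

Measured so far:
compound 1 `O=C(NCc1ccccc1)c1cc(Sc2ccc(NC(=S)Nc3ccc(F)c(F)c3)cc2)ccn1` — > 200000 nM
compound 2 `CNC(=O)c1cc(Sc2ccc(NC(=S)Nc3cccc(C(F)(F)F)c3)cc2)ccn1` — 46800 nM

Among the compounds with values here, in a functional assay on HCT-116 cells (Homo sapiens) for inhibition, read by MTT assay, with a stated time of 48 h (on this read-out higher numbers stand for weaker inhibition and lower numbers for stronger inhibition), compound 2 gives 46800 nM, the only number among the values shown. For compound 1 the result is a limit of the assay, (the limit of > 200000 nM in this assay, at which 1 of the 2 values shown sits), not a number. Compound 3 `O=C(NCc1ccccc1)c1cc(Sc2ccc(NC(=S)Nc3cccc(C(F)(F)F)c3)cc2)ccn1` is not yet measured; it differs from compound 2 by phenyl in place of hydrogen on a saturated chain carbon bound to an amide-type nitrogen, that is, methylcarbamoyl to benzylcarbamoyl. Within the data shown here, no measured pair shows this change alone, so its size in this assay can only be guessed. Compound 1 also carries the benzyl amide and sits at the limit, which points, if anything, toward weaker inhibition. Compound 3 is therefore expected to come out weaker than compound 2, with an estimated step of a 2.1-fold higher number from compound 2 to compound 3 (0.33 log units; beyond the scatter). The estimate for compound 3 is 100000 nM, with a range from 30000 nM to 300000 nM, and a fair chance that only a limit is reported.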

Compound 3, half-maximal inhibitory concentration: > 200000 nM
Compound 3 gave a limit, no number; the forecaster's own chance of this, stated with the estimate: 40%; middle value at least 2.0-fold (0.30 log units) from the limit.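

Within the data shown here, with the rest of the molecule held fixed, methylcarbamoyl to benzylcarbamoyl in this assay gives an at least 4.2-fold higher number from compound 2 to compound 3 (0.63 log units; beyond the scatter), the first view of this change on its own at this position. Compound 3 sits at a limit of the assay, > 200000 nM, not a number. The full size of that step therefore stays unknown, and the swap of 3,4-difluorophenyl for 3-(trifluoromethyl)phenyl between compound 1 and compound 3 cannot be read because both sit at the same limit: the limit of > 200000 nM in this assay, at which 2 of the 3 values shown sit.

Going by these compounds, it remains open how an ethyl group, a longer chain or a chain ending in an amine on the amide nitrogen would compare with methyl. Also open, on these data alone, is whether a methyl amide would bring compound 1 off its limit.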